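The source may hold more compounds than are shown below. What is called first, only, known or untested is meant among the compounds shown, and "the series" means these compounds.

Compound 1 `COc1cccc(Nc2nc(C)cc(N(C)C)n2)c1`: in a physicochemical assay for solubility, read by nephelometry, measured as kinetic solubility (a higher number here means a more soluble compound, a lower number a less soluble compound), compound 1 gives > 250000 nM, which is a limit of the assay rather than a number.
Compound 2 `COc1cc(Nc2nc(C)cc(N(C)C)n2)ccc1F`: in this assay compound 2 gives > 250000 nM, again only a limit.
Compound 3 `Cc1cc(N(C)C)nc(NCC2CCOCC2)n1`: in this assay compound 3 gives > 250000 nM, again only a limit.

Compound 2 therefore stands at the upper edge of what this assay can report, and so do both of its companions; all three values sit at the limit of > 250000 nM in this assay, at which 3 of the 3 values shown sit. Among the compounds with values here, the only measured step that changes a single place, from compound 1 to compound 2, is a step that the two limits leave unreadable from compound 1 to compound 2, because both ends are limits.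

Compound 4 `COc1cc(Nc2nc(C)cc(N3CCCCC3)n2)ccc1F` is the compound still to be measured. It differs from compound 2 in one place: piperidin-1-yl in place of dimethylamino on an aromatic carbon. No measured step among these three compounds swaps one amine for another at that position, so there is no direct precedent for how large a change to expect in this assay, and the one step that is measured gives no readable size at all. The expectation is that compound 4 stays close to the limit, with the step from compound 2 to compound 4 estimated at an at least 1.3-fold lower number from compound 2 to compound 4 (0.14 log units; that floor lies within the scatter). Compound 4 is therefore expected to give about 180000 nM, within a range from 40000 nM to 250000 nM.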

Compound 4, solubility: 160000 nM
Compound 4: the middle estimate sits 1.1-fold (0.05 log units) above what was measured, and the stated range covers the measured number.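

In this assay compound 4 gives 160000 nM, the first real number among the compounds shown, which means that a change at this position can be seen on the scale at all. Compound 2 gives > 250000 nM, which is a limit of the assay and not a number. Piperidin-1-yl in place of dimethylamino, on the aromatic carbon next to the ring nitrogen, therefore gives an at least 1.5-fold lower number from compound 2 to compound 4 (0.19 log units; that floor lies within the scatter); only this lower bound on the size of the step can be stated, and since it lies within the scatter, the swap of one amine for the other, with its added ring, cannot yet be told apart from ordinary variation between repeated measurements.

How far the true values of the other compounds lie above that of compound 4 stays hidden, with most of the series still at the edge of the scale: the limit of > 250000 nM in this assay, at which 3 of the 4 values shown sit. Also open, from the compounds shown here alone, is where the number would fall with a different group on this carbon, such as the smaller pyrrolidin-1-yl ring, a morpholin-4-yl ring with oxygen as a second ring hetero atom, or a group carrying a carboxylic acid.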